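Compound 3 to compound 4: one chloro fewer

A few compounds are considered here, and "the series" means these few. Any claim that something is new, unique, unknown or untested is made for them only; others in the source may bear on it.

Compound 1 (`COc1ccc(-c2nc(C3(S(=O)(=O)c4cccc(Cl)c4)CC3)nc3ccsc23)cn1`), a limit: (> 50000 nM)
Compound 2 (`COc1ccc(-c2nc(C(F)(F)S(=O)(=O)c3cccc(Cl)c3)nc3ccsc23)cn1`), a limit: (> 50000 nM)
Compound 3 (`COc1ccc(-c2nc(CSc3cccc(Cl)c3Cl)nc3ccsc23)cn1`), a limit: (> 50000 nM)

These compounds were tested in (an ADME assay on cells (Homo sapiens) for cytotoxicity, read by resazurin assay, with a stated time of 5 days; on this read-out higher numbers stand for lower toxicity in this test and lower numbers for higher toxicity in this test), and none of them gave a number: the record shows (the limit of > 50000 nM in this assay, at which 3 of the 3 values shown sit). Compound 3 therefore stands only at a limit (> 50000 nM). Compound 4 (`COc1ccc(-c2nc(CSc3cccc(Cl)c3)nc3ccsc23)cn1`) differs from compound 3 by one change (hydrogen in place of chloro on an aromatic carbon), with hydrogen in place of chloro on an aromatic carbon. Among the measured compounds shown here, no measured step shows what such a change does in (this assay). The expected outcome is no shift beyond the usual scatter, in either direction (a number no higher from compound 3 to compound 4 (the limit leaves the size open)). For compound 4 the estimated value is (50000 nM), with an expected range from (25000 nM) to (50000 nM).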

Compound 4, half-maximal cytotoxic concentration: > 10000 nM
Compound 4: no number, only a limit; the forecaster's own chance of this, stated with the estimate: 85%; the middle value lies beyond the limit too.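

Compound 3 and compound 4 both stand only at limits in this assay, so no step can be read between them. The compounds shown leave open whether hydrogen in place of chloro on an aromatic carbon shifts the half-maximal cytotoxic concentration at all.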